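A few compounds are considered here, and "the series" means these few. Any claim that something is new, unique, unknown or untested is made for them only; others in the source may bear on it.

Measured compounds in the series:

- compound 1, `C[C@H](NC(=O)CN(c1nc(Cl)nc2[nH]cnc12)C1CC1)C(=O)OCc1ccccc1`: 41.2%
- compound 2, `O=C(O)[C@@H]1CCCN1C(=O)CN(c1nc(Cl)nc2[nH]cnc12)C1CC1`: 31.5%

Notes. Two compounds have numbers in a functional assay on the whole organism (Tail, strain ICR) with Mus musculus as the target, in the tail flick test, with a stated time of 30 min, at a dose of 25 umol/kg by the oral route; on this read-out lower numbers stand for a weaker effect and higher numbers for a stronger effect at the one dose given. Compound 1 gives 41.2% in this assay, which is the higher of the two numbers. Compound 2 gives 31.5% in this assay; the gap to compound 1 is within the usual scatter, so the two numbers cannot be ranked against each other. Among the compounds with values here, no pair of measured compounds differs in one place only, so no single structural step has been measured.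

The next compound is compound 3, `CC(C)[C@H](NC(=O)CN(c1nc(Cl)nc2[nH]cnc12)C1CC1)C(=O)OCc1ccccc1`. Relative to compound 1 the change is isopropyl in place of methyl on a saturated chain carbon bound to an amide-type nitrogen and a carbonyl carbon. The shared core and the rest of the chain are unchanged. Within the data shown here, with no measured step of any kind to lean on, the expectation rests on the two measured numbers alone and on the small size of the change. The step from compound 1 to compound 3 is expected to be a number 3.8 percentage points higher from compound 1 to compound 3 (within the scatter), that is, no change beyond the scatter, with a slight lean upward. Compound 3 is therefore expected to give about 45% in this assay, with a range from 25% to 65%.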

Compound 3, a percentage reported as activity, at one dose (the size of the read-out at that dose, not a potency): 33.4%
The estimate for compound 3 lay 11.6 percentage points above the measured number; the measured number falls inside the stated range.
By their numbers in this assay, from the lowest: compounds 2, 3 and 1 (each within the scatter of the next).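

In this assay, within the data shown here, the first single-place step, isopropyl in place of methyl on a saturated chain carbon bound to an amide-type nitrogen and a carbonyl carbon, is a number 7.8 percentage points lower from compound 1 to compound 3 (within the scatter). This carbon therefore carries either methyl or isopropyl with no difference beyond the scatter, a result that holds only for the one dose, route and time tested and says nothing about potency. No measurement bearing on the reason for this result is available.

Still open, on these data alone, is whether a longer chain, an amine or a hydroxymethyl group on the same saturated chain carbon would also stay within the scatter of compound 1 or would give a step beyond it. Among these compounds, also open is how the read-out would respond to a change elsewhere in compound 1, such as a free carboxylic acid in place of the benzyl ester, since only this one change at one place can be read so far.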